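The source may report more compounds than this note shows. Statements on the series, on what has been measured and on what is new or still open speak of the compounds shown alone.

Results in a functional assay on A549 cells (Homo sapiens) for cytotoxicity, read by MTT assay, with a stated time of 48 h; a higher number here means a weaker inhibitor, a lower number a stronger inhibitor
compound 1 `COc1c(OCCCCN2CCNCC2)cc(O)c2c(=O)cc(-c3ccccc3)oc12` gives 1740 nM
compound 2 `CCCNCCOc1c(O)cc(O)c2c(=O)cc(-c3ccccc3)oc12` gives "not determined" (no result reported)
compound 3 `COc1ccc(-c2cc(=O)c3c(O)cc(O)c(OC)c3o2)cc1` gives "not determined" (no result reported)

Compound 1 is the only one of these with a number, so it cannot be ranked against anything: compound 2 and compound 3 have no result to compare it with. Compound 4 `CCN(CC)CCCOc1cc(O)c2c(=O)cc(-c3ccccc3)oc2c1OC` has not yet been measured. It keeps the core of compound 1 and changes the side chain, with 4-(piperazin-1-yl)butyl becoming 3-(diethylamino)propyl (diethylamino in place of (piperazin-1-yl)methyl on a saturated chain carbon, three bonds along the chain from an oxygen on an aromatic ring). Cut one way, this puts diethylamino in place of (piperazin-1-yl)methyl on a saturated chain carbon, three bonds along the chain from an oxygen on an aromatic ring. Among the measured compounds shown here, no measured pair of compounds shows what such a change does, so any forecast here is loose. A modest move towards weaker inhibition is expected, and the estimated 2.0-fold higher number from compound 1 to compound 4 (0.30 log units; within the scatter) may not stand far beyond the usual scatter. Compound 4 is expected at 3500 nM (estimated range 1000 nM to 12000 nM).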

Compound 4, half-maximal inhibitory concentration: 1830 nM
Estimate against measurement, compound 4: 1.9-fold (0.28 log units) above; low and high end bracket the measured number.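

Among the compounds shown here, this is the first pair of compounds with two numbers that can be compared. In this assay, exchanging 4-(piperazin-1-yl)butyl for 3-(diethylamino)propyl gives a 1.1-fold higher number from compound 1 to compound 4 (0.02 log units; within the scatter), so this pair does not separate the two side chains, even though diethylamino has no ring and fewer heavy atoms than (piperazin-1-yl)methyl. Nothing available explains this result or links it to any property of either group.

One pair at a single position cannot show how much room for change this side chain allows. A morpholine ring at the end of the chain, a carboxylic acid in place of the amine, or a chain longer than butyl could each give a number beyond the scatter or one within it, and the compounds shown do not tell which.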